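This account rests on a few compounds, and the source may have more. Where it says the series, first, only, none or still open, it means among the compounds named here.

Measured compounds: compound 1 `COc1cc(/C=C2\CCC/C(=C\c3cccc([N+](=O)[O-])c3)C2=O)cc(OC)c1OC` gives 44000 nM; compound 2 `CN(C)c1ccc(/C=C2\CCC/C(=C\c3ccc([N+](=O)[O-])cc3)C2=O)cc1` gives > 500000 nM; compound 3 `CN(C)c1ccc(/C=C2\CCC/C(=C\c3cccc([N+](=O)[O-])c3)C2=O)cc1` gives 10900 nM.

In a functional assay on MOLT-4 cells (Homo sapiens) for cytotoxicity, with a stated time of 72 h (a lower number here means a stronger inhibitor, a higher number a weaker inhibitor), compound 3 is the stronger of the two compounds with a number, and compound 1 gives 44000 nM. For compound 2 the result is only a limit, (the limit of > 500000 nM in this assay, at which 1 of the 3 values shown sits), not a number. The change from compound 3 to compound 2 4-nitrophenyl in place of 3-nitrophenyl on a double-bonded chain carbon bound to a double-bonded ring carbon gave an at least 45-fold higher number from compound 3 to compound 2 (1.66 log units; beyond the scatter). How the cores of compound 1 and compound 3 differ is not broken down here.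

Compound 4 `COc1cc(/C=C2\CCC/C(=C\c3ccc([N+](=O)[O-])cc3)C2=O)cc(OC)c1OC` arises from compound 1 by the same change (4-nitrophenyl in place of 3-nitrophenyl on a double-bonded chain carbon bound to a double-bonded ring carbon). Because the step of an at least 45-fold higher number from compound 3 to compound 2 (1.66 log units; beyond the scatter) already reached the limit from a stronger starting point, compound 4 is expected to show a step of a 20-fold higher number from compound 1 to compound 4 (1.31 log units; beyond the scatter), most likely ending at a limit. Compound 4 is therefore estimated at 900000 nM, between 200000 nM and 5000000 nM.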

Compound 4, half-maximal inhibitory concentration in the MOLT-4 assay: 6420 nM
Compound 4: the middle estimate sits 140-fold (2.15 log units) above what was measured, outside the stated range (below it).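

In the MOLT-4 assay compound 4 gives 6420 nM, and the switch to 4-nitrophenyl gave a 6.9-fold lower number from compound 1 to compound 4 (0.84 log units; beyond the scatter), so on these two cores the same change did not carry over in direction or size: the same change on two cores in the MOLT-4 assay, an at least 45-fold higher number (1.66 log units; beyond the scatter) from compound 3 to compound 2 and a 6.9-fold lower number (0.84 log units; beyond the scatter) from compound 1 to compound 4, at least 310-fold (2.49 log units) apart, beyond the scatter of two such steps. In the MOLT-4 assay compound 2 gives > 500000 nM, which is a limit and not a number, so the step on that core has no exact size. In a physicochemical assay for lipophilicity (on this read-out higher numbers stand for higher lipophilicity and lower numbers for lower lipophilicity), compound 1 gives 5.06 and compound 4 gives 5.08, two values within the scatter of each other. For the compounds shown here, only this one pair of cores is compared, so no rule for other cores follows, and the reason for the split remains unknown.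

The compounds shown leave open how the same change would behave on a core carrying a carboxylic acid or a primary amine. They also leave open whether a nitrile in place of the nitro group would give a similar split.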